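The compounds below may be only part of what the source reports. "The series", "measured", "known", "first", "only" and "open" are said of these compounds alone.

Values in a functional assay on A2780 cells (Homo sapiens) for antiproliferative activity, read by MTT assay, with a stated time of 48 h; a lower number here means a stronger inhibitor, a higher number a weaker inhibitor:
- compound 1 `COc1ccc(-c2cc3c(cn2)[nH]c(=O)n3-c2cc(OC)c(OC)c(OC)c2)cc1F`: 730 nM
- compound 2 `COc1ccc(-c2cc3c(cn2)n(C)c(=O)n3-c2cc(OC)c(OC)c(OC)c2)cc1O`: 1720 nM

Compound 2, at 1720 nM, has the higher of the two numbers, and its gap to compound 1 lies beyond the scatter. These two compounds differ in more than one place, so their gap does not isolate any single change. Compound 3 `COc1ccc(-c2cc3c(cn2)n(C2CC2)c(=O)n3-c2cc(OC)c(OC)c(OC)c2)cc1O` departs from compound 2 as follows: cyclopropyl in place of methyl on an aromatic nitrogen. Among the measured compounds shown here, no measured pair covers this cyclopropyl in place of methyl on an aromatic nitrogen, so no step beyond the scatter is expected in this assay. The expected size of the change is a 1.0-fold higher number from compound 2 to compound 3 (0.02 log units; within the scatter). For compound 3 the estimated value is 1800 nM, with an expected range of 600 nM to 5500 nM.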

Compound 3, half-maximal inhibitory concentration: > 20000 nM
Compound 3: no number, only a limit; the forecaster's own chance of this, stated with the estimate: 5%; at least 11-fold (1.04 log units) between middle value and limit.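

In this assay, among the compounds shown here, the change from methyl to cyclopropyl on the aromatic nitrogen gives an at least 11-fold higher number from compound 2 to compound 3 (1.06 log units; beyond the scatter), the first single change that can be read. This position is therefore sensitive to the group it carries, and this one replacement is enough to take the series out of the measurable range. Compound 3 stands at a limit of the assay, not at a number: the limit of > 20000 nM in this assay, at which 1 of the 3 values shown sits.

On these data alone, what an ethyl or isopropyl group would give on this nitrogen remains open. The compounds shown therefore do not separate the three-membered ring from its extra carbons as the source of the step.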